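The compounds below may be only part of what the source reports. "The series", "measured", "known", "first", "only" and "open" are said of these compounds alone.

The three compounds measured share a urea core carrying a phenylethyl group on one side and a substituted aromatic ring on the other. Compound 1 `Cc1cccc(NC(=O)N[C@@H](C)c2ccccc2)c1` gives 100% in an ADME assay on the whole organism with Oryza sativa as the target, tested at 1 uM; a higher number here means a weaker effect of the compound at the concentration tested, a lower number a stronger effect. Compound 2 `CC(C)c1ccc(NC(=O)N[C@H](C)c2ccccc2)cc1` gives 79% in this assay, and compound 3 `CC(C)c1ccc(NC(=O)N[C@@H](C)c2ccccc2)cc1` gives 96%. For the measured compounds named here, the one step that can be read between neighbours, a number 17 percentage points higher from compound 2 to compound 3 (beyond the scatter), goes with the fact that compounds 2 and 3 differ only in the configuration as drawn and nothing else. Compound 3 therefore stands second highest of the three numbers, close to compound 1 and clearly apart from compound 2.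

Compound 4 `C[C@H](NC(=O)Nc1ccc(C(F)(F)F)cc1)c1ccccc1` is the next step from compound 3: trifluoromethyl in place of isopropyl on an aromatic carbon. Going by the values given here, no measured step involves a change of the group on the aromatic ring, so there is nothing here to set the size or direction of this step; the aromatic substituent is simply exchanged while the configuration of compound 3 is kept. For compound 4 a step of a number 3 percentage points lower from compound 3 to compound 4 (within the scatter) in this assay is expected, which is within the scatter. Compound 4 is thus estimated at 93%, with a likely range from 78% to 100%.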

Compound 4, a percentage reported as activity, at one concentration (the size of the read-out at that concentration, not a potency): 94%
For compound 4 the middle estimate is 1 percentage points below the measured one, and the stated range covers the measured number.
By their numbers in this assay, from the lowest: compound 2; then compounds 4, 3 and 1 (each within the scatter of the next).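

For the compounds shown here, this is the first measured change of the group on the aromatic ring itself, at the carbon para to a large group, with the configuration of compound 3 kept. Trifluoromethyl in place of isopropyl gives a number 2 percentage points lower from compound 3 to compound 4 (within the scatter) in this assay, so this exchange of a group of three carbons for one of a carbon and three fluorines does not separate the two compounds in this read-out. Nothing given here explains this result.

From the compounds shown here alone, it remains open whether a clearly different group on this carbon, such as an amine or a carboxylic acid, would move the number beyond the scatter. Also open, going by these compounds, is whether the opposite configuration, which separates compound 2 from compound 3 when isopropyl is present, would have a similar effect with trifluoromethyl on the ring.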